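A Longer Amine Chain on a Nucleoside Core

This account rests on a few compounds, and the source may have more. Where it says the series, first, only, none or still open, it means among the compounds named here.

Measured so far:
Compound 1 `CN(C)c1nccc2c1ncn2C1O[C@H](CO)[C@@H](O)[C@H]1O`: 10%
Compound 2 `[O-][n+]1ccc2c(c1)ncn2C1O[C@H](CO)[C@@H](O)[C@H]1O`: < 5%
Compound 3 `OC[C@H]1O[C@@H](n2cnc3cnccc32)C[C@@H]1O`: < 5%

Among the measured compounds shown here, in a functional assay on EL4 cells (Mus musculus) for inhibition, tested at 100 uM (on this read-out lower numbers stand for less inhibition and higher numbers for more inhibition at the one concentration tested (going by the name of the read-out)), compound 1 gives 10%, the only number among the three compounds. For compound 2 the assay reports a limit of < 5%. Compound 3 likewise reaches only the limit of < 5% (the limit of < 5% in this assay, at which 2 of the 3 values shown sit). For the measured compounds named here, no two measured compounds differ in one place, so no measured step can be read from these data.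

Compound 4 `CCCCCCNc1nccc2c1ncn2C1O[C@H](CO)[C@@H](O)[C@H]1O` differs from compound 1 by hexylamino in place of dimethylamino on an aromatic carbon. In this assay the step is expected to be small, no larger than the scatter, in either direction. For compound 4 the expected step of a number 5 percentage points higher from compound 1 to compound 4 (within the scatter) leads to an estimate of 15%, between 3% and 35%.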

Compound 4, a percentage reported as inhibition, at one concentration (the size of the read-out at that concentration, not a potency): 14%
For compound 4 the middle estimate is 1 percentage points above the measured one; the range from low to high includes it.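

Replacing dimethylamino with hexylamino on the aromatic carbon next to the ring nitrogen gives, in this assay, a number 4 percentage points higher from compound 1 to compound 4 (within the scatter). This first readable step shows that this position takes a much longer chain, and a hydrogen-bond donor, without a difference that stands out from the scatter. Readings across the set stay low: the limit of < 5% in this assay, at which 2 of the 4 values shown sit.

Chain length and the amine hydrogen change together in this single step, so their separate contributions cannot be told apart. As far as these compounds go, whether an unsubstituted amine, a decyl chain or a carboxylic acid at this position would move the number beyond the scatter remains open.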